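Replacing fluoro with hydrogen on compound 1

This account rests on a few compounds, and the source may have more. Where it says the series, first, only, none or still open, it means among the compounds named here.

Measured so far:
compound 1 (`COc1cc2c(cc1CC=C(C)C)C(=O)C[C@@H](c1ccc(Oc3ccc(F)cc3)cc1)O2`) gives 19%
compound 2 (`COc1cc2c(cc1CC1OC1(C)C)C(=O)C[C@@H](c1ccc(O)cc1)O2`) gives 92%
compound 3 (`COc1cc2c(cc1CC=C(C)C)[C@H](O)C[C@@H](c1ccc(O)cc1)O2`) gives 13%

In a functional assay on PC-3 cells (Homo sapiens) for inhibition, read by sulforhodamine B assay, with a stated time of 48 h, tested at 50 uM (on this read-out higher numbers stand for more inhibition of growth at the one concentration tested and lower numbers for less inhibition of growth), compound 1 stands within the scatter of compound 3, and compound 2 lies well beyond the scatter above compound 1. Compound 4 (`COc1cc2c(cc1CC=C(C)C)C(=O)C[C@@H](c1ccc(Oc3ccccc3)cc1)O2`) has hydrogen in place of fluoro on an aromatic carbon, para to a large group, so 4-fluorophenoxy becomes phenoxy (hydrogen in place of fluoro on an aromatic carbon). For the measured compounds named here, no measured pair shows this change, so the data offer no direct guide. The expectation starts from compound 1 at 19% and foresees no step beyond the scatter in this assay in either direction. The expected change a number 2 percentage points higher from compound 1 to compound 4 (within the scatter) stays within the scatter. Compound 4 is expected at 21% (estimated range 7% to 45%).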

Compound 4, percent growth inhibition at one concentration: 53%
Compound 4: middle estimate off by 32 percentage points, on the low side, outside the stated range (above it).
By their numbers in this assay, from the lowest: compounds 3 and 1 (each within the scatter of the next); then compound 4; then compound 2.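

In this assay, the step from 4-fluorophenoxy to phenoxy is a number 34 percentage points higher from compound 1 to compound 4 (beyond the scatter). For the compounds shown here, this aromatic carbon, para to a large group, is therefore sensitive to substitution: exchanging one fluoro for hydrogen is enough to change growth inhibition beyond the scatter, a result the earlier compounds could not show because none formed a single-place pair. Nothing shown accounts for the size or direction of this step.

From the compounds shown here alone, it remains open how chloro, methoxy or an amine on the same carbon would compare with hydrogen and fluoro. Going by these compounds, with one pair, it is also open whether this step would recur on other members.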